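Swapping the Sulfonyl Substituent: From Phenyl to an Amino Chain

A few compounds are considered here, and "the series" means these few. Any claim that something is new, unique, unknown or untested is made for them only; others in the source may bear on it.

Compound 1 `CC(C)OC(=O)NCCS(=O)(=O)NC(=O)c1ccc(Nc2nc(NC3(c4ccc(Cl)cc4)CC3)nc(OCC(F)(F)F)n2)cc1` gives 71 nm/s in a physicochemical assay for permeability, using PAMPA, at pH 7.4; on this read-out higher numbers stand for higher permeability and lower numbers for lower permeability.
Compound 2 `O=C(NS(=O)(=O)c1ccccc1)c1ccc(Nc2nc(NC3(c4ccc(Cl)cc4)CC3)nc(OCC(F)(F)F)n2)cc1` gives 182 nm/s in this assay.

Among the two measured compounds, compound 2 stands highest in this assay; its nearest neighbour is compound 1, and the step of a 2.6-fold higher number from compound 1 to compound 2 (0.41 log units; beyond the scatter) is the only measured change in this set. Compound 3 `CC(C)(C)CNCCS(=O)(=O)NC(=O)c1ccc(Nc2nc(NC3(c4ccc(Cl)cc4)CC3)nc(OCC(F)(F)F)n2)cc1` has not yet been measured. It differs from compound 2 at the same sulfonyl sulfur: 2-(neopentylamino)ethyl in place of phenyl on a sulfonyl sulfur. Going by the values given here, the one measured step bears directly on this change, since it also replaced a chain carrying a hydrogen-bond donor and acceptor with phenyl and gave a modest rise in this assay. Going the other way, from phenyl back to a chain with one donor and one acceptor, a modest fall is therefore expected for compound 3, likely of at least the size seen in a 2.6-fold higher number from compound 1 to compound 2 (0.41 log units; beyond the scatter) and possibly larger, as the expected step of a 4.6-fold lower number from compound 2 to compound 3 (0.66 log units; beyond the scatter) shows. Compound 3 is estimated at 40 nm/s, with a range from 10 nm/s to 120 nm/s.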

Compound 3, apparent permeability: 651 nm/s
Compound 3: middle estimate off by 16-fold (1.21 log units), on the low side; measured number outside the range, above it.
By their numbers in this assay, from the lowest: compound 1; then compound 2; then compound 3.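

At the sulfonyl sulfur, phenyl does not mark the upper end of the series in this assay: 2-(neopentylamino)ethyl, a chain with a hydrogen-bond donor and a hydrogen-bond acceptor, gives a 3.6-fold higher number from compound 2 to compound 3 (0.55 log units; beyond the scatter) and so reverses the direction that the first step alone might have suggested. Compound 1 and compound 3 differ only on the amine nitrogen, where neopentyl in place of isopropoxycarbonyl gives a 9.2-fold higher number from compound 1 to compound 3 (0.96 log units; beyond the scatter), so the two chains on the sulfonyl sulfur cannot be treated as interchangeable, and compound 2 with its phenyl falls between them in the order of the numbers. The three compounds therefore show that the direction of a change from phenyl to a chain at this position depends on what the chain carries, while nothing measured here explains why these numbers differ.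

On these data alone, it remains open whether the neopentyl group itself matters or whether a smaller alkyl group such as isopropyl or a cyclohexyl ring on the same amine nitrogen would give a similar number. As far as these compounds go, it is also open how the number would respond to a tertiary amine in that chain, to an ether oxygen in place of the amine nitrogen, or to a longer chain on the sulfonyl sulfur.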